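The compounds below may be only part of what the source reports. "The series", "measured", "known", "first", "only" and "open" are said of these compounds alone.

Measured in a functional assay on MGC-803 cells (Homo sapiens) for antiproliferative activity, read by MTT assay, with a stated time of 72 h; on this read-out lower numbers stand for stronger inhibition and higher numbers for weaker inhibition:
compound 1 `CCCSc1nc(Cl)c2c(n1)N(Cc1cccs1)C(C(=O)N1CCN(C)CC1)N2` gives 62300 nM.
compound 2 `CCCSc1nc(Cl)c2c(n1)N(Cc1ccccc1)C(C(=O)Nc1ccccc1)N2` gives 58400 nM.
compound 3 `CCCSc1nc(Cl)c2c(n1)N(Cc1ccccc1)C(C(=O)N1CCN(C)CC1)N2` reaches only an assay limit, > 64000 nM.

Compound 3 thus stands at a limit, not a number; the steps of an at least 1.0-fold higher number from compound 1 to compound 3 (0.01 log units; that floor lies within the scatter) and an at least 1.0-fold higher number from compound 2 to compound 3 (0.03 log units; that floor lies within the scatter) are floored within the scatter because of the limit of > 64000 nM in this assay, at which 1 of the 3 values shown sits. Compound 4 `CCCSc1nc(Cl)c2c(n1)N(Cc1ccccc1)C(C(=O)NCCCc1ccccc1)N2` differs from compound 3 by (3-phenylpropyl)amino in place of 4-methylpiperazin-1-yl on a carbonyl carbon. The step that bears on this change is an at least 1.0-fold higher number from compound 2 to compound 3 (0.03 log units; that floor lies within the scatter), which also swaps the amide substituent on the carbonyl carbon. Compound 2 gives 58400 nM. Compound 3 gives only a limit. No step beyond the scatter is therefore expected in this assay for compound 4, and a limit remains a real possibility. Compound 4 is estimated at 45000 nM (range 15000 nM to 130000 nM). The expected step is an at least 1.4-fold lower number from compound 3 to compound 4 (0.15 log units; that floor lies within the scatter).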

Compound 4, half-maximal inhibitory concentration: 16900 nM
For compound 4 the middle estimate is 2.7-fold (0.43 log units) above the measured one; measured number inside the range.
By their numbers in this assay, from the lowest: compound 4; then compounds 2 and 1 (each within the scatter of the next). At a limit, above all of these: compound 3.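

On the carbonyl carbon, the amide substituent now moves the read-out beyond the scatter in this assay, which neither earlier step showed; with 3-phenylpropyl in place of phenyl on the amide-type nitrogen, the result is a 3.5-fold lower number from compound 2 to compound 4 (0.54 log units; beyond the scatter). Replacing the 4-methylpiperazin-1-yl amide gives an at least 3.7-fold lower number from compound 3 to compound 4 (0.57 log units; beyond the scatter), and this step is only a floor. Compound 3 stands at a limit, > 64000 nM, not a number: the limit of > 64000 nM in this assay, at which 1 of the 4 values shown sits.

Open, on these data alone, is whether benzyl or a longer chain such as 4-phenylbutyl on the amide-type nitrogen lowers the number further. Also open, as far as these compounds go, is whether an amine on that chain keeps the step.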